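The compounds below may be only part of what the source reports. "The series", "measured", "known", "first", "only" and "open" are said of these compounds alone.

In a functional assay on MCF7 cells (Homo sapiens) for inhibition, read by sulforhodamine B assay (a lower number here means a stronger inhibitor, a higher number a weaker inhibitor), compound 1 `O=C1C=C(NCc2ccccc2)C(=O)c2c1nc1n2[C@H]2OC[C@@H](O)[C@H]2OC1` reaches only the limit of the assay, > 8000 nM. Compound 2 `O=C1C=C(Nc2cccc(Cl)c2)C(=O)c2c1nc1n2[C@H]2OC[C@@H](O)[C@H]2OC1` gives 4720 nM. The step of an at least 1.6-fold lower number from compound 1 to compound 2 (0.22 log units; that floor lies within the scatter) comes with 3-chlorophenyl in place of benzyl on an amine nitrogen. Compound 3 `O=C1C=C(N2CCCCC2)C(=O)c2c1nc1n2[C@H]2OC[C@@H](O)[C@H]2OC1` also sits at a limit, > 8000 nM. Between compounds 1 and 3 the step is a step that the two limits leave unreadable from compound 1 to compound 3, and from compound 2 the step of an at least 1.6-fold higher number from compound 2 to compound 3 (0.22 log units; that floor lies within the scatter) follows piperidin-1-yl in place of (3-chlorophenyl)amino on a double-bonded ring carbon. So compound 3 stands only at a limit, and the same is true of compound 1 (the limit of > 8000 nM in this assay, at which 2 of the 3 values shown sit).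

Compound 4 `O=C1C=C(N2CCC2)C(=O)c2c1nc1n2[C@H]2OC[C@@H](O)[C@H]2OC1` differs from compound 3 by azetidin-1-yl in place of piperidin-1-yl on a double-bonded ring carbon. Among the measured compounds shown here, the only step touching a cyclic amine at this place is an at least 1.6-fold higher number from compound 2 to compound 3 (0.22 log units; that floor lies within the scatter), a move to the limit; no measured pair compares two such rings, so nothing suggests a shift beyond the scatter. Compound 4 is therefore expected to stay at or near the limit, with an estimated step that the limit leaves unreadable from compound 3 to compound 4. The estimate for compound 4 in this assay is 9000 nM, from 3000 nM to 30000 nM.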

Compound 4, half-maximal inhibitory concentration: > 16000 nM
Compound 4: no number, only a limit (the forecaster's own chance of this, stated with the estimate: 70%); middle value at least 1.7-fold (0.24 log units) away from the limit.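

In this assay compound 4 again reaches only a limit of the assay, > 16000 nM. Among the compounds shown here, the change to azetidin-1-yl on a double-bonded ring carbon gives an at least 3.3-fold higher number from compound 2 to compound 4 (0.53 log units; beyond the scatter), the first step at this place that is clearly beyond the scatter, so compound 4 is a weaker inhibitor than compound 2, which keeps its (3-chlorophenyl)amino group. The steps that join compound 4 to compound 1 and to compound 3 cannot be read, because each links two limits: the limit of > 8000 nM in this assay, at which 2 of the 4 values shown sit.

As far as these compounds go, how azetidin-1-yl and piperidin-1-yl rank against each other remains open, since neither ring gives a number. Also open, from the compounds shown here alone, is how other groups at this place would behave, such as a morpholine ring or a phenylamino group with a nitrile in place of the chlorine.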